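The source may report more compounds than this note shows. Statements on the series, on what has been measured and on what is new or still open speak of the compounds shown alone.

Compound 1 `COc1cccc(CNCCCNc2ccnc3cc(-c4ccccc4)ccc23)c1O`: 32000 nM
Compound 2 `COc1cccc(CNCCCNc2ccnc3cc(Oc4ccccc4)ccc23)c1O`: 14500 nM
Compound 3 `COc1cccc(CNCCCNc2ccnc3cc(Cc4ccc(F)cc4)ccc23)c1O`: 4200 nM

In a physicochemical assay for solubility, with a stated time of 18 h, at pH 7.4 (on this read-out lower numbers stand for lower solubility and higher numbers for higher solubility), compound 3 gives the lowest number of the three. The steps of a 7.6-fold lower number from compound 1 to compound 3 (0.88 log units; beyond the scatter) and a 3.5-fold lower number from compound 2 to compound 3 (0.54 log units; beyond the scatter) place it below both others, each beyond the scatter. Going by the values given here, compound 4 `COc1cccc(CNCCCNc2ccnc3cc(Cc4ccc(C#N)cc4)ccc23)c1O` differs from compound 3 by cyano in place of fluoro on an aromatic carbon; the change sits on the 4-fluorobenzyl group, so none of the measured steps, all of which alter the group on the shared core itself, bears on it directly. Those steps were modest, and the incoming cyano brings one hydrogen-bond acceptor. A small rise, possibly within the scatter, is therefore expected, a 1.5-fold higher number from compound 3 to compound 4 (0.19 log units; within the scatter). Compound 4 is estimated at 6500 nM, within 2500 nM to 16000 nM.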

Compound 4, solubility: 4200 nM
Estimate against measurement, compound 4: 1.5-fold (0.19 log units) above; the measured number falls inside the stated range.
By their numbers in this assay, from the lowest: compounds 3 and 4 (each within the scatter of the next); then compound 2; then compound 1.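

In this assay, cyano in place of fluoro on the aromatic carbon para to a large group gives no change at the digits printed from compound 3 to compound 4 (within the scatter). The steps of a 3.5-fold lower number from compound 2 to compound 4 (0.54 log units; beyond the scatter) and a 7.6-fold lower number from compound 1 to compound 4 (0.88 log units; beyond the scatter) match those seen with 4-fluorobenzyl, so among these four compounds the differences go with the group on the shared core, not with this para substituent. Nothing available explains why fluoro and cyano read alike here. Two substituents at this place cannot show whether an amine or a carboxylic acid there would read the same in this assay.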